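From methoxy to cyanomethyl on the side chain

This account rests on a few compounds, and the source may have more. Where it says the series, first, only, none or still open, it means among the compounds named here.

In a functional assay on HT-29 cells (Homo sapiens) for inhibition, read by luminescence and CellTiter-Glo, with a stated time of 24 h (on this read-out higher numbers stand for an effect only at larger amounts of compound and lower numbers for an effect already at smaller amounts), compound 1 (`CCCCn1nc(C(=O)N[C@H]2COc3ccccc3N(C)C2=S)nc1Cc1ccccc1`) gives 510 nM and compound 2 (`COCCn1nc(C(=O)N[C@H]2COc3ccccc3N(C)C2=S)nc1Cc1ccccc1`) gives 566 nM, so compound 2 stands level with compound 1 within the scatter. Compound 3 (`CN1C(=S)[C@@H](NC(=O)c2nc(Cc3ccccc3)n(CCCC#N)n2)COc2ccccc21`) carries cyanomethyl in place of methoxy on a saturated chain carbon, two bonds along the chain from an aromatic nitrogen. For the measured compounds named here, the one measured step at this place, a 1.1-fold higher number from compound 1 to compound 2 (0.05 log units; within the scatter), stayed within the scatter, so no step beyond the scatter is expected in this assay. The expected value for compound 3 is 540 nM, with a range of 250 nM to 1150 nM. This estimate means a 1.0-fold lower number from compound 2 to compound 3 (0.02 log units; within the scatter).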

Compound 3, half-maximal effective concentration: 2400 nM
Estimate against measurement, compound 3: 4.4-fold (0.65 log units) below; the measured number lies above the stated range.
By their numbers in this assay, from the lowest: compounds 1 and 2 (each within the scatter of the next); then compound 3.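

In this assay the end of this side chain turns out to matter: where ethyl and methoxy had stood level, the nitrile brings a 4.2-fold higher number from compound 2 to compound 3 (0.63 log units; beyond the scatter) and a 4.7-fold higher number from compound 1 to compound 3 (0.67 log units; beyond the scatter). Among these compounds, the 3-cyanopropyl chain of compound 3 alone stands apart, beyond the scatter from both others. Nothing available explains this step.

On these data alone, whether the higher number follows from the nitrile itself or from something particular to the 3-cyanopropyl chain remains open. So does how an amine or a carboxylic acid at the chain end, or a longer chain, would read.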